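Swapping the outer ring substituent on a thromboxane antagonist

A few compounds are considered here, and "the series" means these few. Any claim that something is new, unique, unknown or untested is made for them only; others in the source may bear on it.

Measured so far:
Compound 1, `O=C(O)CC/C=C\CO[C@H]1C(OCc2ccc(-c3ccccc3)cc2)CC[C@@H]1N1CCCCCC1` — 12.6 nM
Compound 2, `CC(=O)NCc1ccc(-c2ccc(COC3CC[C@H](N4CCCCCC4)[C@H]3OC/C=C\CCC(=O)O)cc2)cc1` — 2.51 nM

In a functional assay on blood for antagonist activity at thromboxane A2 receptor (Homo sapiens) (a higher number here means weaker binding, a lower number tighter binding), compound 2 gives the lowest of the two numbers, and its nearest neighbour is compound 1, which in this assay gives 12.6 nM. Among the measured compounds shown here, the one measured step, a 5.0-fold lower number from compound 1 to compound 2 (0.70 log units; beyond the scatter), shows that adding acetamidomethyl on the outer aromatic ring was worth a modest, real gain.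

Compound 3, `O=C(O)CC/C=C\CO[C@H]1C(OCc2ccc(-c3ccccc3CCO)cc2)CC[C@@H]1N1CCCCCC1`, is not yet measured. It differs from compound 2 in one place: 2-(2-hydroxyethyl)phenyl in place of 4-(acetamidomethyl)phenyl on an aromatic carbon. The outer ring keeps one hydrogen-bond donor and one hydrogen-bond acceptor, but the group is now 2-(2-hydroxyethyl)phenyl rather than 4-(acetamidomethyl)phenyl, and the substituent is smaller by two heavy atoms. For the measured compounds named here, only the step from compound 1 to compound 2 bears on this, and it tells how much the original substituent gained, not what a differently placed hydroxyethyl does. A number between those of compound 1 and compound 2 is therefore expected, with wide uncertainty. For compound 3 the estimate in this assay is 6.3 nM, within 2 nM to 20 nM, an expected step of a 2.5-fold higher number from compound 2 to compound 3 (0.40 log units; beyond the scatter).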

Compound 3, dissociation constant: 2 nM
Estimate against measurement, compound 3: 3.2-fold (0.50 log units) above, and the stated range covers the measured number.
By their numbers in this assay, from the lowest: compounds 3 and 2 (each within the scatter of the next); then compound 1.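

In this assay, putting 2-hydroxyethyl on the outer ring gives a 6.3-fold lower number from compound 1 to compound 3 (0.80 log units; beyond the scatter) and so shows that the gain is not tied to acetamidomethyl alone. Replacing 4-(acetamidomethyl)phenyl with 2-(2-hydroxyethyl)phenyl gives a 1.3-fold lower number from compound 2 to compound 3 (0.10 log units; within the scatter) and leaves the two compounds indistinguishable in this assay, even though the entering group has fewer heavy atoms and no nitrogen, while the counts of hydrogen-bond donors and acceptors stay the same. Nothing measured here explains why two such different groups give such similar numbers.

The compounds shown do not reveal whether the terminal hydroxyl of 2-hydroxyethyl contributes to the gain, or whether the two-carbon chain alone would be enough. A plain ethyl group would address that question directly, while an amine or a carboxylic acid at the end of the same chain, or a longer chain carrying the hydroxyl, would show how much the outer ring substituent can vary before the number in this assay moves.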